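Cyclohexyloxy for Propyl on the Carbonyl Carbon

A few compounds are considered here, and "the series" means these few. Any claim that something is new, unique, unknown or untested is made for them only; others in the source may bear on it.

Compound 1, `CCCC(=O)C1=C(C)NC(=O)NC1c1ccco1`, was tested in an assay on membranes from HeLa cells for displacement of a labelled ligand from adenosine receptor A3 (Homo sapiens), read by scintillation counting, with a stated time of 180 min, tested at 1 uM (on this read-out lower numbers stand for less inhibition and higher numbers for more inhibition at the one concentration tested (going by the name of the read-out)), where compound 1 gives 1%. Among the measured compounds shown here, its only measured neighbour is compound 2, `CCCC(=O)C1=C(C)NC(=O)NC1c1ccsc1`, and in this assay compound 2 gives 1%. The step of no change at the digits printed from compound 1 to compound 2 (within the scatter) shows nothing beyond the scatter. Compound 1 therefore stands level with compound 2 at the digits reported, and both sit at the floor of the read-out.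

Compound 3, `CC1=C(C(=O)OC2CCCCC2)C(c2ccco2)NC(=O)N1`, has not yet been measured. It differs from compound 1 in this way: cyclohexyloxy in place of propyl on a carbonyl carbon. For the measured compounds named here, the one measured step concerns an exchange on a saturated ring carbon and leaves the carbonyl carbon untouched, so no measured step bears on the change that compound 3 carries. Going by the values given here, what can be said is that compound 1 and compound 2 both lie at the floor and that no step between them exceeds the scatter. For compound 3 the expected step is therefore a number 4 percentage points higher from compound 1 to compound 3 (within the scatter), none beyond the scatter. The estimate for compound 3 in this assay is 5%, with a range from 0% to 25%.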

Compound 3, a percentage reported as inhibition, at one concentration (the size of the read-out at that concentration, not a potency): 4%
The estimate for compound 3 lay 1 percentage points above the measured number; the measured number falls inside the stated range.
By their numbers in this assay, from the lowest: compounds 1, 2 and 3 (each within the scatter of the next).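

In this assay, among the compounds shown here, cyclohexyloxy in place of propyl on the carbonyl carbon gives a number 3 percentage points higher from compound 1 to compound 3 (within the scatter) and so provides the first measured step at this position, one that stays inside the scatter. The entering group brings more heavy atoms, a six-membered non-aromatic ring of carbon only and a hydrogen-bond acceptor that propyl does not have, yet compound 3 remains with compound 1 near the floor of the read-out at the one concentration tested. No measured evidence is available to explain this outcome.

From the compounds shown here alone, with all three compounds near the floor, it remains open whether any other group on the carbonyl carbon, such as ethoxy, benzyloxy or an amine, would give inhibition beyond the scatter in this assay at this concentration. It also remains open whether cyclohexyloxy would give the same result with thiophen-3-yl in place of furan-2-yl on the saturated ring carbon, and whether the compounds shown would separate at a higher concentration.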